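Positional Methoxy Shift on the Benzyl Urea Series

The source may hold more compounds than are shown below. What is called first, only, known or untested is meant among the compounds shown, and "the series" means these compounds.

Measured so far:
compound 1, `O=C(NCc1ccccc1Br)N1C(=O)c2ccccc2S1(=O)=O`: 0.253 h
compound 2, `COc1ccccc1CNC(=O)N1C(=O)c2ccccc2S1(=O)=O`: 1.12 h

Both were run in a physicochemical assay for pharmacokinetics; on this read-out higher numbers stand for a longer-lived compound and lower numbers for a shorter-lived compound. For the measured compounds named here, compound 2 gives the higher of the two numbers, with compound 1 as its only neighbour; the step of a 4.4-fold higher number from compound 1 to compound 2 (0.65 log units; beyond the scatter) is the single measured step in the set and concerns a methoxy in place of bromo on an aromatic carbon.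

Compound 3, `COc1cccc(CNC(=O)N2C(=O)c3ccccc3S2(=O)=O)c1`, is not yet measured. Its change from compound 2 is 3-methoxyphenyl in place of 2-methoxyphenyl on a saturated chain carbon bound to an amide-type nitrogen. The same atoms are present in both, joined differently.

Going by the values given here, no measured step bears on this change: the only step known, a 4.4-fold higher number from compound 1 to compound 2 (0.65 log units; beyond the scatter), swaps one group for another rather than moving a group within the same ring, so it gives no direct guide. With nothing in the series to suggest a direction, the expected step of a 1.0-fold lower number from compound 2 to compound 3 (0.01 log units; within the scatter) is none beyond the scatter. On these data alone, compound 3 is therefore estimated at 1.1 h in this assay, with a range of 0.5 h to 2.5 h, the width reflecting that the positional change is untested here.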

Compound 3, half-life: 0.523 h
Estimate against measurement, compound 3: 2.1-fold (0.32 log units) above, and the stated range covers the measured number.
By their numbers in this assay, from the lowest: compound 1; then compound 3; then compound 2.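

In this assay, 3-methoxyphenyl in place of 2-methoxyphenyl on a saturated chain carbon bound to an amide-type nitrogen gives a 2.1-fold lower number from compound 2 to compound 3 (0.33 log units; beyond the scatter), so the read-out in this series responds to where the methoxy group sits on the ring even when the atoms stay the same. 3-Methoxyphenyl in place of 2-bromophenyl at the same place gives a 2.1-fold higher number from compound 1 to compound 3 (0.32 log units; beyond the scatter), so both methoxy compounds give higher numbers than the bromo compound, and compound 3 stands between compound 1 and compound 2 rather than matching the step of a 4.4-fold higher number from compound 1 to compound 2 (0.65 log units; beyond the scatter). No supporting data bear on why the two methoxy isomers differ, and the difference stays an observation on the half-life alone.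

For the compounds shown here, still open is whether bromo responds to the same ring move as methoxy does, since the series offers only one bromo compound and the positional comparison rests on a single pair. Also open, on these data alone, is how other groups on this ring, such as a nitrile, an amine or a carboxylic acid, or a longer chain at the saturated carbon, would sit on this read-out relative to the methoxy pair.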